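The compounds below may be only part of what the source reports. "The series", "measured", "known", "first", "only" and "open" are said of these compounds alone.

- compound 1 `O=C(NCCCNc1cc(-c2cn(-c3ccccc3)nc2-c2cccc(O)c2)ccn1)Nc1ccc(F)cc1` gives 4040 nM
- compound 2 `O=C(NCCCNc1cc(-c2cn(-c3ccccc3)nc2-c2cccc(O)c2)ccn1)Nc1cccc(C(F)(F)F)c1` gives 4320 nM

These two numbers come from a functional assay on HCT-15 cells (Homo sapiens) for antiproliferative activity, read by sulforhodamine B assay, with a stated time of 48 h (a lower number here means a stronger inhibitor of growth, a higher number a weaker inhibitor of growth), and are the only ones so far. For the measured compounds named here, compound 1 stands level with the one other measured compound, and a 1.1-fold higher number from compound 1 to compound 2 (0.03 log units; within the scatter) is the whole gap between them. Compound 3 `COc1cccc(-c2nn(-c3ccccc3)cc2-c2ccnc(NCCCNC(=O)Nc3ccc(F)cc3)c2)c1` differs from compound 1 by a single change (methyl in place of hydrogen on an oxygen on an aromatic ring) that turns 3-hydroxyphenyl into 3-methoxyphenyl. Going by the values given here, the one measured step placed 3-(trifluoromethyl)phenyl in place of 4-fluorophenyl on an amide-type nitrogen, so it does not touch this oxygen, and no measured pair tests the new change. The starting point therefore stays compound 1 at 4040 nM and only a small shift toward a higher number is expected, a cautious guess rather than a measured trend. The expected move is a 1.4-fold higher number from compound 1 to compound 3 (0.13 log units; within the scatter) and no more than that is assumed. For compound 3 the estimate is 5500 nM with 2200 nM to 13000 nM as the estimated range.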

Compound 3, concentration for total growth inhibition: > 37000 nM
Compound 3 was reported as a limit; the forecaster's own chance of this, stated with the estimate: 5%; at least 6.7-fold (0.82 log units) between middle value and limit.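

For the compounds shown here, putting a methyl on the oxygen of the aromatic ring, so that hydroxy becomes methoxy, is the first change here to move the result in this assay beyond the scatter, giving an at least 9.1-fold higher number from compound 1 to compound 3 (0.96 log units; beyond the scatter). For compound 3, the printed > 37000 nM is a limit and not a number: the limit of > 37000 nM in this assay, at which 1 of the 3 values shown sits. Growth inhibition in this small set therefore depends on what sits on this oxygen, whereas replacing 4-fluorophenyl with 3-(trifluoromethyl)phenyl on the amide-type nitrogen gave a 1.1-fold higher number from compound 1 to compound 2 (0.03 log units; within the scatter).

The compounds shown leave open whether the methyl itself matters or whether any replacement of the hydroxy hydrogen would have the same result. An ethyl on the same oxygen, or an amine in place of the hydroxy group, would help separate these two readings.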